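Working notes: aryl exchange from compound 3 to compound 4

A few compounds are considered here, and "the series" means these few. Any claim that something is new, unique, unknown or untested is made for them only; others in the source may bear on it.

- compound 1 `CC(C)=CCOc1ccc2c(c1)OC(c1ccccc1F)CC2=O` 6360 nM
- compound 2 `CC(C)=CCOc1ccc2c(c1)OC(c1ccc(Br)cc1)CC2=O` 8120 nM
- compound 3 `CC(C)=CCOc1cc(O)c2c(c1)OC(c1ccccc1F)CC2=O` 5300 nM

In a functional assay (a higher number here means a weaker inhibitor, a lower number a stronger inhibitor), compound 3 at 5300 nM lies within the scatter of both other values, so the three cannot be ranked. Compound 4 `CC(C)=CCOc1cc(O)c2c(c1)OC(c1ccc(Cl)cc1Cl)CC2=O` has 2,4-dichlorophenyl in place of 2-fluorophenyl on a saturated ring carbon, with 2,4-dichlorophenyl in place of 2-fluorophenyl on a saturated ring carbon as the counted difference. Going by the values given here, the only measured exchange at that carbon gave a 1.3-fold higher number from compound 1 to compound 2 (0.11 log units; within the scatter) and the hydroxy exchange gave a 1.2-fold lower number from compound 1 to compound 3 (0.08 log units; within the scatter) so neither left the scatter. The expected step is a 1.1-fold higher number from compound 3 to compound 4 (0.04 log units; within the scatter) and no shift beyond the scatter is expected in this assay for this change. Compound 4 is estimated at 5800 nM with a range from 2500 nM to 13000 nM expected for it.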

Compound 4, half-maximal inhibitory concentration: 3340 nM
Beside the measured number, compound 4's estimate is 1.7-fold (0.24 log units) above it, within the range that was stated.
By their numbers in this assay, from the lowest: compounds 4, 3, 1 and 2 (each within the scatter of the next, the first and the last beyond it).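

In this assay the exchange of 2-fluorophenyl for 2,4-dichlorophenyl on the saturated ring carbon gives a 1.6-fold lower number from compound 3 to compound 4 (0.20 log units; within the scatter) and so stays within the scatter. This carbon has now taken a second aryl exchange, this time on the hydroxy-bearing compound, and neither exchange has left the scatter. No supporting data bear on this step.

From the compounds shown here alone, whether an amine or a carboxylic acid on the aryl ring would move the number beyond the scatter remains open. The same holds for a saturated alkyl chain replacing that ring.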